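Moving a methyl from a methoxy in nitroimidazole sulfonamides

The source may hold more compounds than are shown below. What is called first, only, known or untested is meant among the compounds shown, and "the series" means these compounds.

Compound 1 `COCCNS(=O)(=O)CCn1ccnc1[N+](=O)[O-]` and compound 2 `O=[N+]([O-])c1nccn1CCS(=O)(=O)NCCO` share one core; compound 3 `COCCNS(=O)(=O)CCn1cncc1[N+](=O)[O-]` and compound 4 `O=[N+]([O-])c1cncn1CCS(=O)(=O)NCCO` share another, and the difference between the two cores is not broken down here. In a functional assay on HCT-116 cells (Homo sapiens) for cytotoxicity, read by sulforhodamine B assay, with stated times of 4 h and 5 days (a higher number here means a weaker inhibitor, a lower number a stronger inhibitor), compound 1 gives 400000 nM and compound 2 gives 800000 nM. The change between them is hydrogen in place of methyl on an oxygen on a saturated carbon, and that step, a 2.0-fold higher number from compound 1 to compound 2 (0.30 log units; within the scatter), is small. Compound 3 gives 4400000 nM in this assay, which stands beyond the scatter from both compound 1 and compound 2. Compound 4 carries the same change on the second core: hydrogen in place of methyl on an oxygen on a saturated carbon. Since the step from compound 1 to compound 2 was a 2.0-fold higher number from compound 1 to compound 2 (0.30 log units; within the scatter), compound 4 is expected to sit near compound 3, with an estimated step of a 1.6-fold higher number from compound 3 to compound 4 (0.20 log units; within the scatter). In this assay compound 4 is therefore estimated at 7000000 nM, between 3000000 nM and 16000000 nM.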

Compound 4, half-maximal inhibitory concentration in the HCT-116 assay: 5300000 nM
For compound 4 the middle estimate is 1.3-fold (0.12 log units) above the measured one; low and high end bracket the measured number.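

In the HCT-116 assay the change from methoxy to hydroxy gives a 1.2-fold higher number from compound 3 to compound 4 (0.08 log units; within the scatter), so it is small on this core too, and the two steps do not differ: the same change on two cores in the HCT-116 assay, a 2.0-fold higher number (0.30 log units; within the scatter) from compound 1 to compound 2 and a 1.2-fold higher number (0.08 log units; within the scatter) from compound 3 to compound 4, 1.7-fold (0.22 log units) apart, within the scatter of two such steps

The same change does move a second measured property on the core of compound 3, in a physicochemical assay for solubility, read by HPLC (a lower number here means a less soluble compound, a higher number a more soluble compound), where compound 3 gives 24400000 nM and compound 4 gives 69300000 nM: the measured solubility of compound 3, 24400000 nM, and of compound 4, 69300000 nM, a 2.8-fold higher number (0.45 log units; beyond the scatter)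

This shows that the step carried over between these two cores in cytotoxicity, but it does not show that it would carry to any other core, and the solubility step rests on a single pair.

The compounds shown leave open whether an amine or a longer chain in place of the 2-hydroxyethyl would also leave the number in the HCT-116 assay little changed. They also leave open what the difference between the two cores contributes.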